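Swapping the Difluorocyclohexyl Amide for a Fluorophenyl Amide

This account rests on a few compounds, and the source may have more. Where it says the series, first, only, none or still open, it means among the compounds named here.

Compound 1 `O=C(C1CCC(F)(F)CC1)N1CC(c2nc(-c3cccc(Cl)c3)no2)C1` was tested in an assay on HEK293 cells for negative allosteric modulation of metabotropic glutamate receptor 5 (Homo sapiens), read by FLIPR (a higher number here means a weaker inhibitor, a lower number a stronger inhibitor), where compound 1 gives only a limit, > 10000 nM. Compound 2 `Cc1cccc(-c2noc(C3CN(C(=O)C4CCC(C(F)(F)F)CC4)C3)n2)c1` likewise returns a limit in this assay, > 10000 nM. Compound 3 `O=C(C1CCCCC1)N1CC(c2nc(-c3cccc(F)c3)no2)C1` also returns a limit in this assay, > 10000 nM. All three shown values sit at the limit of > 10000 nM in this assay, at which 3 of the 3 values shown sit, so compound 1 stands at the same limit as the others and no ordering among them can be drawn. Compound 4 `O=C(c1ccc(F)cc1)N1CC(c2nc(-c3cccc(Cl)c3)no2)C1` has not yet been measured; it differs from compound 1 by 4-fluorophenyl in place of 4,4-difluorocyclohexyl on a carbonyl carbon. With every shown value a limit, there is no measured step to guide the size of this change in this assay. Compound 4 is expected to stay near the limit, around 15000 nM with a range from 3000 nM to 60000 nM, which amounts to an expected step that the limit leaves unreadable from compound 1 to compound 4, within the scatter.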

Compound 4, half-maximal inhibitory concentration in the metabotropic glutamate receptor 5 assay: 4000 nM
Compound 4: middle estimate off by 3.8-fold (0.57 log units), on the high side; measured number inside the range.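

For the compounds shown here, putting 4-fluorophenyl in place of 4,4-difluorocyclohexyl on this carbonyl carbon gives the first readable step in the metabotropic glutamate receptor 5 assay: an at least 2.5-fold lower number from compound 1 to compound 4 (0.39 log units; beyond the scatter). In a physicochemical assay for solubility, read by HPLC, in phosphate buffer, with a stated time of 4 h (a lower number here means a less soluble compound, a higher number a more soluble compound), compound 1 gives 130000000 nM and compound 4 gives 47000 nM. The same swap therefore also brings a large step in the physicochemical assay, a 2800-fold lower number from compound 1 to compound 4 (3.44 log units; beyond the scatter).

The compounds shown leave open whether a pyridine ring or a cyclohexyl ring bearing an amine at this carbonyl carbon would give a readable number in the metabotropic glutamate receptor 5 assay without so large a step in the physicochemical assay.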